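This account rests on a few compounds, and the source may have more. Where it says the series, first, only, none or still open, it means among the compounds named here.

Two cinnamate-type compounds have been measured. Compound 1, `COC(=O)/C=C/c1cccc(O)c1`, gives 850000 nM in an ADME assay on RAW264.7 cells (Mus musculus) for inhibition, read by trypan blue exclusion, with a stated time of 48 h; a higher number here means a weaker inhibitor of growth, a lower number a stronger inhibitor of growth. Compound 2, `COC(=O)/C=C/c1ccccc1OCC=C(C)C`, gives 2600000 nM in this assay and so carries the higher of the two numbers, the step up from compound 1 lying beyond the scatter of repeated measurements. Compound 3, `CC(C)=CCOc1ccccc1/C=C/C(=O)O`, has not yet been measured; it differs from compound 2 in one place, (hydrogen in place of methyl on an oxygen next to a carbonyl group), so that the methoxycarbonyl group of compound 2 becomes a carboxy group. Among the compounds with values here, no measured pair in this set shows the same change, so there is no direct guide to its size. One would expect the step from compound 2 to compound 3 in this assay to be modest, a 1.2-fold higher number from compound 2 to compound 3 (0.06 log units; within the scatter), and most likely not beyond the scatter. Compound 3 is therefore estimated to give about 3000000 nM in this assay, with a plausible range from 1000000 nM to 10000000 nM.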

Compound 3, concentration for 50% growth inhibition: 1680000 nM
Estimate against measurement, compound 3: 1.8-fold (0.25 log units) above; measured number inside the range.
By their numbers in this assay, from the lowest: compounds 1, 3 and 2 (each within the scatter of the next, the first and the last beyond it).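

Within the data shown here, replacing methoxycarbonyl with carboxy gives the first one-place comparison in this set: in this assay the change amounts to a 1.5-fold lower number from compound 2 to compound 3 (0.19 log units; within the scatter) and so stays within the scatter. At this place on the shared core, hydrogen in place of methyl on the oxygen next to the carbonyl group therefore leaves compound 2 and compound 3 indistinguishable in this read-out, although this rests on a single pair. No supporting measurement is available to explain this result or to show how either group behaves in the cells.

As far as these compounds go, whether an ethyl ester, a longer chain on the same oxygen or a primary amide in place of the carboxy group would also stay within the scatter remains open. So does whether the same change would give a similar step on the core of compound 1.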